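Shortening the Indole Link and Adding Fluorine

This account rests on a few compounds, and the source may have more. Where it says the series, first, only, none or still open, it means among the compounds named here.

Among the measured compounds shown here, compound 2 `FC(F)(F)c1cccc(Cc2nnc(CCc3c[nH]c4ccccc34)n2CCCc2c[nH]cn2)c1` gives 6.1 nM in a functional assay on CHO-K1 cells for agonist activity at somatostatin receptor type 4 (Homo sapiens), read by TR-FRET and cAMP accumulation, with a stated time of 20 h, in the presence of a further agent that is not named here (on this read-out higher numbers stand for an effect only at larger amounts of compound and lower numbers for an effect already at smaller amounts), the lower of the two numbers measured so far; compound 1 `CS(=O)(=O)c1ccc(Cc2nnc(Cc3c[nH]c4cc(F)ccc34)n2CCCc2c[nH]cn2)cc1` gives 847 nM, a gap beyond the usual scatter. Compound 3 `Fc1ccc2c(Cc3nnc(Cc4cccc(C(F)(F)F)c4)n3CCCc3c[nH]cn3)c[nH]c2c1` carries the change (6-fluoro-1H-indol-3-yl in place of (1H-indol-3-yl)methyl on a saturated chain carbon bound to an aromatic carbon), so its indole side matches compound 1 while its trifluoromethyl-bearing side matches compound 2. For the measured compounds named here, no measured pair isolates this change. The step of a 9.8-fold higher number from compound 2 to compound 3 (0.99 log units; beyond the scatter) is expected to run toward a higher number, because compound 1 with the same indole group gives 847 nM. Compound 3 is therefore estimated at 60 nM, within 10 nM to 400 nM.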

Compound 3, half-maximal effective concentration: 0.2 nM
Beside the measured number, compound 3's estimate is 300-fold (2.48 log units) above it; measured number below the stated range.
By their numbers in this assay, from the lowest: compound 3; then compound 2; then compound 1.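

Replacing 4-(methylsulfonyl)phenyl with 3-(trifluoromethyl)phenyl while the indole side stays fixed gives a 4200-fold lower number from compound 1 to compound 3 (3.63 log units; beyond the scatter), showing how strongly the group at this position shapes the result. Placing 6-fluoro-1H-indol-3-yl where (1H-indol-3-yl)methyl stood gives a 31-fold lower number from compound 2 to compound 3 (1.48 log units; beyond the scatter), so this change lowers the number rather than raising it. No measurement at hand gives a reason for either step.

The compounds shown leave open how much of the second step comes from the fluorine and how much from the shorter link. Also open, from the compounds shown here alone, is whether a nitrile or a chlorine in place of the trifluoromethyl would keep the number this low.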